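The compounds below may be only part of what the source reports. "The series", "measured", "known", "first", "only" and "open" are said of these compounds alone.

Measured compounds:
compound 1 `Nc1nc(-c2ccc(Cl)cc2)cn1/N=C/c1cc2ccccc2nc1Cl` — > 50000 nM
compound 2 `Cc1ccc2nc(Cl)c(/C=N/n3cc(-c4ccc(Cl)cc4)nc3N)cc2c1` — 38900 nM

In a functional assay on DLD-1 cells (Homo sapiens) for cytotoxicity, read by MTT assay, with a stated time of 48 h (a lower number here means a stronger inhibitor, a higher number a weaker inhibitor), compound 1 returns only a limit, > 50000 nM, and not a number. Going by the values given here, compound 2 gives 38900 nM in this assay, and this is the only real number in the set. The remaining value, that of compound 1, is a limit (the limit of > 50000 nM in this assay, at which 1 of the 2 values shown sits). Among the compounds with values here, the single measured step is an at least 1.2-fold lower number from compound 1 to compound 2 (0.10 log units; that floor lies within the scatter); as a comparison against a limit it fixes only a floor, and that floor lies within the scatter, so it carries little weight.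

Compound 3 `Cc1ccc2nc(Cl)c(/C=N/n3cc(-c4cccs4)nc3N)cc2c1` is the next structure. It differs from compound 2 by thiophen-2-yl in place of 4-chlorophenyl on an aromatic carbon. Within the data shown here, no measured step touches the group on this aromatic carbon; the only step in hand concerns the methyl on a different ring and does not bear on this replacement. With nothing to argue for a shift either way, the expectation for this assay is a step no larger than the scatter, while the nearness of compound 2 to the limit leaves a fair chance that compound 3 reports only a limit. The estimate for compound 3 is 45000 nM, range 15000 nM to 150000 nM, expected as a 1.2-fold higher number from compound 2 to compound 3 (0.06 log units; within the scatter).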

Compound 3, half-maximal inhibitory concentration: 8990 nM
Compound 3: middle estimate off by 5.0-fold (0.70 log units), on the high side; measured number outside the range, below it.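

In this assay, going by these compounds alone, the group on this aromatic carbon of the five-membered aromatic ring with 2 nitrogen is the first place where a single change registers clearly: thiophen-2-yl in place of 4-chlorophenyl gives a 4.3-fold lower number from compound 2 to compound 3 (0.64 log units; beyond the scatter). Within the data shown here, the only earlier step, the methyl on a different ring, gave an at least 1.2-fold lower number from compound 1 to compound 2 (0.10 log units; that floor lies within the scatter), so it fixed a floor and no more, and it said nothing about this position. The new step is also the only one in the series read between two real numbers, the other resting on a limit: the limit of > 50000 nM in this assay, at which 1 of the 3 values shown sits.

The swap changes several things at once, from a six-membered ring of carbon only to a five-membered ring with sulfur, and it also removes the chlorine, so a plain phenyl, a furan-2-yl or a thiophen-3-yl on this carbon would be needed to tell which of these changes matters. Also open, going by these compounds, are whether the step holds without the methyl on the shared core, and what a basic group such as an aminomethyl or a morpholine would do on this same carbon.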